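The source may hold more compounds than are shown below. What is called first, only, known or untested is meant among the compounds shown, and "the series" means these compounds.

Of the compounds shown here, two have been measured so far in a functional assay on MDA-MB-231 cells (Homo sapiens) for inhibition, read by MTT assay, with a stated time of 72 h, tested at 20 uM; a higher number here means more inhibition at the concentration tested (going by the name of the read-out), a lower number less inhibition. Compound 1 `c1cc(N2CCCC2)nc(Nc2ccc(Oc3ncnc4sccc34)cc2)n1` gives 24.7%. Compound 2 `c1cc(N2CCCCC2)nc(Nc2ccc(Oc3ncnc4ccsc34)cc2)n1` gives 45.7%, the higher of the two numbers, and its gap to compound 1 lies beyond the usual scatter. Compound 3 `c1cc(N2CCCC2)nc(Nc2ccc(Oc3ncnc4ccsc34)cc2)n1` keeps the core of compound 2 and differs in one group: pyrrolidin-1-yl in place of piperidin-1-yl on an aromatic carbon. Compound 1 carries the same pyrrolidin-1-yl group on a different core, so the two measured numbers cannot tell the ring change apart from the core change. A modest downward step is expected, a number 9.7 percentage points lower from compound 2 to compound 3 (within the scatter), close to the scatter. Compound 3 is therefore estimated at 36%, within a range from 18% to 54%.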

Compound 3, a percentage reported as inhibition, at one concentration (the size of the read-out at that concentration, not a potency): 14.3%
The estimate for compound 3 lay 21.7 percentage points above the measured number, outside the stated range (below it).
By their numbers in this assay, from the lowest: compound 3; then compound 1; then compound 2.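

In this assay, pyrrolidin-1-yl in place of piperidin-1-yl on the shared core gives a number 31.4 percentage points lower from compound 2 to compound 3 (beyond the scatter) and shows that this aromatic carbon is sensitive to a change from a six-membered to a five-membered ring. With pyrrolidin-1-yl held constant, the core change can now be read alone: it gives a number 10.4 percentage points lower from compound 1 to compound 3 (beyond the scatter) and is also beyond the scatter, so ring and core each matter. Nothing measured here explains either step.

Going by these compounds, whether piperidin-1-yl would also raise the number on the core of compound 1 remains open. So does the effect of a morpholine ring or an open-chain dimethylamino group at this carbon.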